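The source may report more compounds than this note shows. Statements on the series, on what has been measured and on what is new or still open speak of the compounds shown alone.

Measured in a toxicity assay on KB cells (Homo sapiens) for cytotoxicity, read by fluorescence, with a stated time of 3 days; on this read-out higher numbers stand for an effect only at larger amounts of compound and lower numbers for an effect already at smaller amounts:
Compound 1 `CCCCOC(=O)CNC(=O)[C@H](CSc1ccc([N+](=O)[O-])cc1[N+](=O)[O-])NC(=O)CC[C@H](NC(=O)CC(C)C)C(=O)OCCCC`; compound 1 gives 59.6 uM.
Compound 2 `CCCCOC(=O)CNC(=O)[C@H](CSc1ccc([N+](=O)[O-])cc1[N+](=O)[O-])NC(=O)CC[C@H](Nc1ccc([N+](=O)[O-])cc1[N+](=O)[O-])C(=O)OCCCC`; compound 2 gives > 300 uM, a limit of the assay.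
Compound 3 `CCCCOC(=O)CNC(=O)[C@H](CSc1ccc([N+](=O)[O-])cc1[N+](=O)[O-])NC(=O)CC[C@H](NC(=O)CCc1ccccc1)C(=O)OCCCC`; compound 3 gives > 300 uM, a limit of the assay.

Compound 3 thus stands at the limit of > 300 uM in this assay, at which 2 of the 3 values shown sit, with no number of its own. Of the steps among the measured compounds, the one bearing directly on the position in question is an at least 5.0-fold higher number from compound 1 to compound 3 (0.70 log units; beyond the scatter), which shows that exchanging the group on the saturated chain carbon bound to a carbonyl carbon moves the series from a readable number to the limit. The other steps, an at least 5.0-fold higher number from compound 1 to compound 2 (0.70 log units; beyond the scatter) and a step that the two limits leave unreadable from compound 2 to compound 3, concern the amine nitrogen and give no further reading for this position.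

Compound 4 `CCCCOC(=O)CNC(=O)[C@H](CSc1ccc([N+](=O)[O-])cc1[N+](=O)[O-])NC(=O)CC[C@H](NC(=O)COc1ccccc1)C(=O)OCCCC` differs from compound 3 by phenoxy in place of benzyl on a saturated chain carbon bound to a carbonyl carbon. Since the aryl-bearing variant compound 3 already sits at the limit, no step beyond the scatter is expected from compound 3 to compound 4: a number no higher from compound 3 to compound 4 (the limit leaves the size open). For compound 4 in this assay the estimate is 300 uM, within 100 uM to 900 uM, most likely reported again as a limit.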

Compound 4, concentration for half-maximal effect: > 300 uM
Compound 4 ended at the assay's limit (the forecaster's own chance of this, stated with the estimate: 70%); the middle value lies on the limit itself.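

In this assay, phenoxy in place of isopropyl on the saturated chain carbon bound to a carbonyl carbon gives an at least 5.0-fold higher number from compound 1 to compound 4 (0.70 log units; beyond the scatter), a second exit from the readable range at this position, after benzyl in compound 3. Of the groups shown here, only the isopropyl of compound 1 keeps a number of its own, and the value of compound 4 is a limit of the assay, not a number. Exchanging benzyl for phenoxy therefore separates nothing, and the steps among compound 2, compound 3 and compound 4 cannot be read: the limit of > 300 uM in this assay, at which 3 of the 4 values shown sit.

On these data alone, whether an amine, a carboxylic acid or a longer alkyl chain at this position would keep a readable number remains open. So does any real difference between benzyl and phenoxy, which this limit hides.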